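The source may report more compounds than this note shows. Statements on the series, on what has been measured and on what is new or still open speak of the compounds shown alone.

Of the compounds shown here, three have been measured in a functional assay for inhibition, with Rattus norvegicus as the target; a lower number here means a stronger inhibitor, a higher number a weaker inhibitor. Compound 1 `CNc1nc(Cl)nc2c1ncn2CC(COC(C)=O)COC(=O)c1ccccc1` gives 6900 nM. Compound 2 `CNc1nc(Cl)nc2c1ncn2CC(COC(=O)c1ccccc1)COP(=O)(O)O` gives 18000 nM. Compound 2 differs from compound 1 by a group of 4 heavy atoms (3 oxygen, 1 phosphorus; no ring) in place of a group of 3 heavy atoms (2 carbon, 1 oxygen; no ring), on an oxygen on a saturated carbon. This change made a step of a 2.6-fold higher number from compound 1 to compound 2 (0.42 log units; beyond the scatter). Compound 3 `CNc1nc(Cl)nc2c1ncn2[C@H]1CC(OC(C)=O)[C@]2(COC(C)=O)CC12` gives 29000 nM. Compound 3 and compound 2 lie within the scatter of each other, while compound 1 gives a lower number than compound 3, beyond the scatter. The difference between the core of compound 1 and the core of compound 3 is not broken down here.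

Compound 4 `CNc1nc(Cl)nc2c1ncn2[C@H]1CC(OP(=O)(O)O)[C@]2(COC(C)=O)CC12` has not yet been measured in this assay. It differs from compound 3 by a group of 4 heavy atoms (3 oxygen, 1 phosphorus; no ring) in place of a group of 3 heavy atoms (2 carbon, 1 oxygen; no ring), on an oxygen on a saturated carbon. Among the measured compounds shown here, this is the same kind of change as the one from compound 1 to compound 2, but the surroundings differ: in compound 3 the saturated carbon's other neighbour is a saturated ring carbon, whereas in compound 1 it is a saturated chain carbon. The step from compound 3 to compound 4 is expected to be a 2.1-fold higher number from compound 3 to compound 4 (0.32 log units; beyond the scatter), resting on the earlier step of a 2.6-fold higher number from compound 1 to compound 2 (0.42 log units; beyond the scatter), with the changed surroundings leaving room for a somewhat different size. Compound 4 is therefore estimated to give 60000 nM, most likely between 22000 nM and 160000 nM.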

Compound 4, inhibition constant: 16000 nM
Compound 4: middle estimate off by 3.8-fold (0.57 log units), on the high side, outside the stated range (below it).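

In this assay, putting the group of 4 heavy atoms in place of the acetyl on the core of compound 3 gives a 1.8-fold lower number from compound 3 to compound 4 (0.26 log units; within the scatter), so on this core the swap leaves the number within the scatter. The same swap does not behave alike on the two cores: the same change on two cores in this assay, a 2.6-fold higher number (0.42 log units; beyond the scatter) from compound 1 to compound 2 and a 1.8-fold lower number (0.26 log units; within the scatter) from compound 3 to compound 4, 4.7-fold (0.67 log units) apart, beyond the scatter of two such steps. Among the compounds shown here, this shows that, in this series, the step seen on the core of compound 1 is a poor guide to the step on the core of compound 3, but with only two pairs it does not show which feature of the cores lies behind the gap, or what the swap would do on a third core.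

The compounds shown leave open whether a different group in place of that acetyl, such as a longer acyl chain or a chain carrying an amine, would also depend on the core. They also leave open what happens when the other acetyl of compound 4 is changed.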